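The compounds below may be only part of what the source reports. "The series", "measured", "known", "first", "only" and "open" are said of these compounds alone.

Two compounds of the series carry a number in a functional assay, read by spectrophotometry, with a stated time of 15 min; a lower number here means a stronger inhibitor, a higher number a weaker inhibitor. Compound 1 `Cc1nc2c3ccccc3ccc2c2nc3c(ccc4ccccc43)c(-c3nccnc3N)c12` gives 47.8 ug/mL. Compound 2 `Cc1nc2c3ccccc3ccc2c2nc3c(ccc4ccccc43)c(-c3ccc(O)cc3)c12` gives 44.1 ug/mL; this is the lowest of the two numbers shown, yet the step of a 1.1-fold lower number from compound 1 to compound 2 (0.03 log units; within the scatter) lies within the scatter, so the two compounds are not separated by this assay. Compound 3 `Cc1ccc(-c2c3ccc4ccccc4c3nc3c2c(C)nc2c4ccccc4ccc32)cc1` has not yet been measured. It differs from compound 2 by methyl in place of hydroxy on an aromatic carbon. Going by the values given here, the only measured step, a 1.1-fold lower number from compound 1 to compound 2 (0.03 log units; within the scatter), also exchanges the group on an aromatic carbon and moved this assay hardly at all; no step that exchanges only a hydroxy for a methyl is available. The change to compound 3 is therefore expected to stay within the scatter, with no clear direction. The estimate for compound 3 in this assay is 45 ug/mL, in a range from 20 ug/mL to 100 ug/mL. This corresponds to an expected step of a 1.0-fold higher number from compound 2 to compound 3 (0.01 log units; within the scatter).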

Compound 3, half-maximal inhibitory concentration: 68.7 ug/mL
Estimate against measurement, compound 3: 1.5-fold (0.18 log units) below; low and high end bracket the measured number.
By their numbers in this assay, from the lowest: compounds 2, 1 and 3 (each within the scatter of the next).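

Working notes on the position: in this assay, the 4-hydroxyphenyl to 4-methylphenyl exchange isolates a single atom change, para to a large group, and the hydrogen-bond donor and acceptor counted on hydroxy leave with it (a 1.6-fold higher number from compound 2 to compound 3 (0.19 log units; within the scatter)). Replacing 3-aminopyrazin-2-yl with 4-methylphenyl on the shared core also stays inside the usual spread (a 1.4-fold higher number from compound 1 to compound 3 (0.16 log units; within the scatter)). With these steps, all three groups at this position remain unseparated in this assay, and no supporting measurement is available to interpret this result.

On these data alone, whether an amine, a carboxylic acid or a longer alkyl chain in place of methyl on this ring would separate from these three groups remains open. Also open, as far as these compounds go, is whether the same hydroxy to methyl exchange would read alike elsewhere on the shared core.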